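Trimming a tert-butyl ester in a dihydropyridine series

This account rests on a few compounds, and the source may have more. Where it says the series, first, only, none or still open, it means among the compounds named here.

Of the compounds shown here, three with a shared core have been tested in an assay on isolated protein (strain albino) for antagonist activity at Voltage-dependent L-type calcium channel subunit alpha-1C (Cavia porcellus); on this read-out lower numbers stand for stronger inhibition and higher numbers for weaker inhibition. Compound 1 `CSc1ncc(C2C(C(=O)OC3CCCC3)=C(C)NC(C)=C2C(=O)OC2CCCC2)n1Nc1ccccc1` carries two cyclopentyl esters and gives 425 nM. Compound 2 `CSc1ncc(C2C(C(=O)OC(C)C)=C(C)NC(C)=C2C(=O)OC(C)C)n1Nc1ccccc1` carries two isopropyl esters and gives 2.16 nM. Compound 3 `CSc1ncc(C2C(C(=O)OC(C)(C)C)=C(C)NC(C)=C2C(=O)OC(C)(C)C)n1Nc1ccccc1` carries two tert-butyl esters and gives 121 nM. Among these, compound 3 stands second highest; its nearest neighbour is compound 1, whose higher number lies beyond the scatter, and its furthest is compound 2, whose lower number lies far beyond the scatter.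

Compound 4 `CSc1ncc(C2C(C(=O)OC(C)C)=C(C)NC(C)=C2C(=O)OC(C)(C)C)n1Nc1ccccc1` has not been measured. It differs from compound 3 in one place: hydrogen in place of methyl on a saturated chain carbon bound to an oxygen next to a carbonyl group and two saturated chain carbons. Cut one bond further out, this reads tert-butyl to isopropyl at one ester, so compound 4 sits halfway between compound 3 and compound 2 in structure. Because compound 2 gives 2.16 nM and compound 3 gives 121 nM, a clear downward step beyond the scatter is expected. The estimated step of an 8.1-fold lower number from compound 3 to compound 4 (0.91 log units; beyond the scatter) places compound 4 at an expected 15 nM, with a range from 4 nM to 60 nM.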

Compound 4, half-maximal inhibitory concentration: 68.2 nM
For compound 4 the middle estimate is 4.5-fold (0.66 log units) below the measured one; the whole stated range lies below it.
By their numbers in this assay, from the lowest: compound 2; then compounds 4 and 3 (each within the scatter of the next); then compound 1.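

In this assay, trading one tert-butyl ester for an isopropyl ester gives a 1.8-fold lower number from compound 3 to compound 4 (0.25 log units; within the scatter), so this single change does not separate the two compounds. Read from the other end, the same methyl added to one ester gives a 32-fold higher number from compound 2 to compound 4 (1.50 log units; beyond the scatter), so the size of this change depends on what the other ester carries, and among these compounds a single tert-butyl ester is enough to lose most of what two isopropyl esters give. Nothing available explains why the two steps differ so much.

The compounds shown leave open how a smaller methyl or ethyl ester, or a longer chain such as an n-butyl ester, would read in this series. Also open, going by these compounds, is whether a cyclopentyl ester paired with an isopropyl ester follows the same uneven pattern.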